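The source may hold more compounds than are shown below. What is called first, only, known or untested is meant among the compounds shown, and "the series" means these compounds.

Measured compounds:

- compound 1 `COc1cc(-c2nn(-c3cccc(NC(=O)Nc4cc(C(F)(F)F)cc(C(F)(F)F)c4)c3)cc2-c2ccncc2)ccc1Cl`: 3540 nM
- compound 2 `COc1cc(-c2nn(-c3cccc(NC(=O)Nc4ccc(Cl)c(Cl)c4)c3)cc2-c2ccncc2)ccc1Cl`: > 50000 nM, a limit of the assay
- compound 3 `O=C(Nc1cccc(-n2cc(-c3ccncc3)c(-c3ccc(Cl)c(O)c3)n2)c1)Nc1ccc(Cl)c(Cl)c1`: > 32500 nM, a limit of the assay

Within the data shown here, in a functional assay on SF-539 cells (Homo sapiens) for inhibition, read by sulforhodamine B assay, with a stated time of 48 h (on this read-out lower numbers stand for higher toxicity in this test and higher numbers for lower toxicity in this test), compound 1 is the only member of the series with a number of its own, 3540 nM. For compound 2 this assay returns only a limit, > 50000 nM, which is the limit of > 50000 nM in this assay, at which 1 of the 3 values shown sits. For compound 3 the result is likewise a limit, > 32500 nM, which is the limit of > 32500 nM in this assay, at which 1 of the 3 values shown sits. Compound 2 and compound 3 differ in one place, (hydrogen in place of methyl on an oxygen on an aromatic ring), but with both values sitting at limits the step between them is a step that the two limits leave unreadable from compound 2 to compound 3, so it yields no readable size for the change.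

The difference between the core of compound 1 and the core of compound 2 is not broken down here.

Compound 4 `O=C(Nc1cccc(-n2cc(-c3ccncc3)c(-c3ccc(Cl)c(O)c3)n2)c1)Nc1cc(C(F)(F)F)cc(C(F)(F)F)c1` is the untested member. It differs from compound 1 by hydrogen in place of methyl on an oxygen on an aromatic ring, the same change that turns compound 2 into compound 3. Among the measured compounds shown here, the one measured example of this change gives no readable size, so the expectation for compound 4 rests only on the value of compound 1, 3540 nM, with wide uncertainty. The expected step from compound 1 to compound 4 in this assay is taken as a 1.3-fold higher number from compound 1 to compound 4 (0.10 log units; within the scatter). Compound 4 is therefore estimated at 4500 nM in this assay, with a range from 1200 nM to 20000 nM.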

Compound 4, concentration lethal to 50% of the cells: 2890 nM
Compound 4: middle estimate off by 1.6-fold (0.19 log units), on the high side; measured number inside the range.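

In this assay, among these compounds, replacing methoxy with hydroxy on the core of compound 1, that is, 4-chloro-3-methoxyphenyl to 4-chloro-3-hydroxyphenyl, gives a 1.2-fold lower number from compound 1 to compound 4 (0.09 log units; within the scatter), so on this core the two compounds cannot be told apart and this pair is the only readable example of the change. On the core of compound 2 the same change has no readable size, as compound 2 stands at a limit of the assay: the limit of > 50000 nM in this assay, at which 1 of the 4 values shown sits. Compound 3 also stands at a limit of the assay, so the result on the core of compound 1 is not shown to carry over to the core of compound 2, and no rule for moving the change between cores can be drawn from these compounds: the limit of > 32500 nM in this assay, at which 1 of the 4 values shown sits.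

The compounds shown leave open how this assay responds when an amine, a carboxylic acid or an ethoxy group takes the place of the methoxy on either core. They also leave open whether numbers rather than limits on the core of compound 2 would give a step of similar size to the one read on the core of compound 1.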